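Shortening the carboxy chain: compound 3 to compound 4

The source may hold more compounds than are shown below. What is called first, only, known or untested is meant among the compounds shown, and "the series" means these compounds.

In a functional assay on MDA-MB-453 cells (Homo sapiens) for cytotoxicity, read by MTT assay, with a stated time of 72 h (a higher number here means a weaker inhibitor, a lower number a stronger inhibitor), compound 1 (`CC1=CCC[C@H]2[C@](C)(CC3=CC(=O)C=CC3=O)[C@@H](C)CC[C@]12C`), with hydrogen on the double-bonded ring carbon, gives 16700 nM as its reading. Compound 2 (`CC1=CCC[C@H]2[C@](C)(CC3=CC(=O)C=C(N[C@@H](CC(C)C)C(=O)O)C3=O)[C@@H](C)CC[C@]12C`), with (1-carboxy-3-methylbutyl)amino on that carbon, gives 10900 nM as its reading, and the step (a 1.5-fold lower number from compound 1 to compound 2 (0.19 log units; within the scatter)) does not separate the two. Compound 3 (`CC1=CCC[C@H]2[C@](C)(CC3=CC(=O)C=C(NCCC(=O)O)C3=O)[C@@H](C)CC[C@]12C`), with (2-carboxyethyl)amino on that carbon, gives 3310 nM and stands lowest of the three, with steps (a 5.0-fold lower number from compound 1 to compound 3 (0.70 log units; beyond the scatter)) and (a 3.3-fold lower number from compound 2 to compound 3 (0.52 log units; beyond the scatter)).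

The change to compound 4 (`CC1=CCC[C@H]2[C@](C)(CC3=CC(=O)C=C(NCC(=O)O)C3=O)[C@@H](C)CC[C@]12C`) is (carboxy in place of carboxymethyl on a saturated chain carbon bound to an amine nitrogen), carboxy in place of carboxymethyl on a saturated chain carbon bound to an amine nitrogen, so 2-carboxyethyl becomes carboxymethyl. Among the compounds with values here, no measured step shortens a chain alone. The nearest evidence is the modest exchange on the amine nitrogen (a 3.3-fold lower number from compound 2 to compound 3 (0.52 log units; beyond the scatter)), while the step from hydrogen to a carboxy-bearing amino group is also modest (a 5.0-fold lower number from compound 1 to compound 3 (0.70 log units; beyond the scatter)). A small step toward a higher number is therefore expected in this assay, with the size (a 1.7-fold higher number from compound 3 to compound 4 (0.22 log units; within the scatter)). For compound 4 the estimated value is 5500 nM within an expected range from 2400 nM to 12000 nM in this assay.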

Compound 4, half-maximal inhibitory concentration: 5840 nM
Estimate against measurement, compound 4: 1.1-fold (0.03 log units) below; low and high end bracket the measured number.
By their numbers in this assay, from the lowest: compounds 3, 4, 2 and 1 (each within the scatter of the next, the first and the last beyond it).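

In this assay, carboxy in place of carboxymethyl on a saturated chain carbon bound to an amine nitrogen (a 1.8-fold higher number from compound 3 to compound 4 (0.25 log units; within the scatter)) does not separate the two chain lengths at this position. Hydrogen in place of isobutyl on a saturated chain carbon bound to an amine nitrogen and a carbonyl carbon (a 1.9-fold lower number from compound 2 to compound 4 (0.27 log units; within the scatter)) likewise leaves no separation, while (carboxymethyl)amino in place of hydrogen on a double-bonded ring carbon (a 2.9-fold lower number from compound 1 to compound 4 (0.46 log units; beyond the scatter)) is a second step beyond the scatter from hydrogen, joining compound 3, with compound 2 going against this pattern. No supporting data bear on the reason for these readings.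

On these data alone, whether a longer chain, such as 3-carboxypropyl, would stay level with these readings remains open. So does whether an amide or a methyl ester in place of the carboxylic acid would retain the step from hydrogen.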